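Acetylphenyl replacing pyrazinyl on the trifluoromethyl benzothiazole amide

A few compounds are considered here, and "the series" means these few. Any claim that something is new, unique, unknown or untested is made for them only; others in the source may bear on it.

Compound 1 `O=C(c1nc2cc(C(F)(F)F)ccc2s1)N1CCN(c2cnccn2)CC1` gives 28.1% in an ADME assay on RAW264.7 cells (Mus musculus) for cytotoxicity, read by MTT assay, with a stated time of 72 h, tested at 50 ug/mL (on this read-out higher numbers stand for more inhibition at the one concentration tested (going by the name of the read-out) and lower numbers for less inhibition), the lowest of the three numbers; compound 2 `COc1ccc(N2CCN(C(=O)c3nc4cc(Cl)ccc4s3)CC2)cc1` gives 42.8% and compound 3 `O=C(c1nc2ccccc2s1)N1CCN(c2cnccn2)CC1` gives 65.3%, both beyond the scatter above it. Going by the values given here, the one single-point step measured, a number 37.2 percentage points higher from compound 1 to compound 3 (beyond the scatter), concerns the aromatic carbon and not the amine nitrogen. Compound 4 `CC(=O)c1ccc(N2CCN(C(=O)c3nc4cc(C(F)(F)F)ccc4s3)CC2)cc1` differs from compound 1 by 4-acetylphenyl in place of pyrazin-2-yl on an amine nitrogen in a ring. Among the compounds with values here, no measured step bears directly on this change; compound 2, which also carries an aryl group on the ring nitrogen but differs in a second place, shows only that such a compound can sit above compound 1. A small upward step of a number 7.9 percentage points higher from compound 1 to compound 4 (within the scatter) is therefore expected, with wide uncertainty, giving for compound 4 an estimated 36% (range 15% to 60%).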

Compound 4, a percentage reported as inhibition, at one concentration (the size of the read-out at that concentration, not a potency): 30.6%
The estimate for compound 4 lay 5.4 percentage points above the measured number; the range from low to high includes it.
By their numbers in this assay, from the lowest: compounds 1 and 4 (each within the scatter of the next); then compound 2; then compound 3.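

In this assay, going by these compounds alone, 4-acetylphenyl in place of pyrazin-2-yl on an amine nitrogen in a ring comes with a number 2.5 percentage points higher from compound 1 to compound 4 (within the scatter), the first single-place reading at this position. On the core of compound 1, this position therefore takes either aromatic ring with no difference beyond the scatter. No measurement in hand accounts for this result.

As far as these compounds go, whether an amine or a carboxylic acid in place of the acetyl group, or a longer chain on the ring nitrogen, would shift the number remains open. Also open, from the compounds shown here alone, is whether the same swap behaves alike on the core of compound 3.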